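This account rests on a few compounds, and the source may have more. Where it says the series, first, only, none or still open, it means among the compounds named here.

Measured in a functional assay for inhibition, with Mus musculus as the target; a higher number here means a weaker inhibitor, a lower number a stronger inhibitor:
- compound 1 `C=C1CCC(C(C)C)=CC2C1CC[C@]2(C)O`: 23000 nM
- compound 2 `CC(C)C1=CC2C(CC[C@]2(C)O)[C@@](O)(CO)CC1`: 68000 nM

Of these two, compound 2 stands highest at 68000 nM, which makes it the weaker inhibitor of the pair. Compound 1 lies lower, and the gap between them is beyond the scatter.

Next in the series is compound 3 `CC(C)C1=CC2C(CC[C@]2(C)O)[C@@](O)(CS(=O)(=O)O)CC1`, still to be measured in this assay. Relative to compound 2, the change is sulfo in place of hydroxy on a saturated chain carbon bound to a saturated ring carbon. Seen one bond further out, hydroxymethyl becomes sulfomethyl, and the rest of the shared core stays the same.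

For the measured compounds named here, no measured pair isolates this change, so its direction cannot be read from the data. The expectation therefore starts from compound 2 at 68000 nM, with no step beyond the scatter expected and a wide range allowed on either side. The expected step is a 1.2-fold higher number from compound 2 to compound 3 (0.07 log units; within the scatter). For compound 3 the estimated value is 80000 nM, with an expected range of 25000 nM to 250000 nM.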

Compound 3, half-maximal inhibitory concentration: > 100000 nM
Compound 3: a limit, no number (the forecaster's own chance of this, stated with the estimate: 25%); at least 1.2-fold (0.09 log units) between middle value and limit.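

In this assay compound 3 carries a limit and not a number: > 100000 nM. The change from hydroxymethyl to sulfomethyl gives an at least 1.4-fold higher number from compound 2 to compound 3 (0.16 log units; that floor lies within the scatter), so this first reading of the change records only a floor, and that floor does not separate sulfo from hydroxy. What is new is that, on a saturated chain carbon bound to a saturated ring carbon, sulfo brings no gain in inhibition over hydroxy, and that the series has now reached the end of the readable range: the limit of > 100000 nM in this assay, at which 1 of the 3 values shown sits.

From the compounds shown here alone, whether the true value of compound 3 lies close to its limit or far beyond it stays open, and with it the real size of this step. Also open, going by these compounds, is how a carboxylic acid or an amine would fare at this same place, which would show whether the result is particular to sulfo or extends to other groups.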